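Ring Size of the Amine Carrier in Compound 1

The source may hold more compounds than are shown below. What is called first, only, known or untested is meant among the compounds shown, and "the series" means these compounds.

Compound 1 `FC(F)(F)c1cc(NC[C@H]2CCCN2)c2cn[nH]c2c1` is the strongest of the three measured compounds: in an assay for inhibition of Indoleamine 2,3-dioxygenase 1 (Homo sapiens), with stated times of 10 min and 60 min, tested at 100 uM (a lower number here means a weaker effect, a higher number a stronger effect of the compound at the concentration tested), compound 1 gives 83%. Compound 2 `O=C(O)CNc1cccc(CNc2cc(C(F)(F)F)cc3[nH]ncc23)c1` gives 8% in this assay, and compound 3 `OC1CCCC(Nc2cccc(CNc3cc(C(F)(F)F)cc4[nH]ncc34)c2)C1` gives 2%. For the measured compounds named here, the only measured step between compounds differing in one place is a number 6 percentage points lower from compound 2 to compound 3 (within the scatter), a change on the other nitrogen of the carrier chain, far from the saturated amine.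

Compound 4 `FC(F)(F)c1cc(NC[C@H]2CCCCN2)c2cn[nH]c2c1` has not yet been measured. It differs from compound 1 by piperidin-2-yl in place of pyrrolidin-2-yl on a saturated chain carbon bound to a nitrogen on an aromatic ring. Going by the values given here, no measured step touches this part of the molecule, so nothing measured points to a large change in this assay. Compound 4 is therefore expected to give a step of a number 8 percentage points lower from compound 1 to compound 4 (within the scatter). The estimated value of compound 4 is 75%, in a range from 50% to 92%.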

Compound 4, a percentage reported as inhibition, at one concentration (the size of the read-out at that concentration, not a potency): 69%
The estimate for compound 4 lay 6 percentage points above the measured number; low and high end bracket the measured number.
By their numbers in this assay, from the lowest: compounds 3 and 2 (each within the scatter of the next); then compound 4; then compound 1.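

At this position, on a saturated chain carbon bound to a nitrogen on an aromatic ring, this assay shows that piperidin-2-yl in place of pyrrolidin-2-yl gives a number 14 percentage points lower from compound 1 to compound 4 (beyond the scatter). The ring size of the amine carrier therefore affects the read-out, yet the six-membered ring retains a substantial effect at the concentration tested. No available measurement gives a cause for this step.

The compounds shown leave open how an azetidin-2-yl ring or an open-chain aminoethyl group would behave in this place. They also leave open whether the step would hold for the opposite stereocentre.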